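Adding a Diethylamino Group to Compound 2

The compounds below may be only part of what the source reports. "The series", "measured", "known", "first", "only" and "open" are said of these compounds alone.

Of the compounds shown here, two have been measured in a functional assay on HCT-116 cells (Homo sapiens) for cytotoxicity, read by MTT assay, with a stated time of 72 h; a lower number here means a stronger inhibitor, a higher number a weaker inhibitor. Compound 1 `COc1ncc(-c2ccc3nccc(N4CCCC4)c3c2)cc1NS(=O)(=O)c1ccc(F)cc1F` gives 3320 nM in this assay. Compound 2 `COc1ncc(-c2ccc3nccc(-c4ccc(C)cc4)c3c2)cc1NS(=O)(=O)c1ccc(F)cc1F` carries a 4-methylphenyl group where compound 1 carries a pyrrolidin-1-yl group, and in this assay compound 2 gives 2540 nM. The step of a 1.3-fold lower number from compound 1 to compound 2 (0.12 log units; within the scatter) lies within the scatter, so the two numbers cannot be told apart; compound 2 merely shows the lower of the two.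

Compound 3 `CCN(CC)Cc1ccc(-c2ccnc3ccc(-c4cnc(OC)c(NS(=O)(=O)c5ccc(F)cc5F)c4)cc23)cc1` differs from compound 2 by diethylamino in place of hydrogen on a saturated chain carbon bound to an aromatic carbon, so the 4-methylphenyl group becomes a 4-((diethylamino)methyl)phenyl group. Going by the values given here, no measured step touches this place: the single measured step concerns a different position and was itself within the scatter, so nothing seen so far speaks directly to this change. The step from compound 2 to compound 3 is therefore expected to be a 1.4-fold lower number from compound 2 to compound 3 (0.15 log units; within the scatter) in this assay, no clear shift beyond the scatter, with a broad range either way. Compound 3 is estimated at 1800 nM, between 500 nM and 6500 nM.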

Compound 3, half-maximal inhibitory concentration: 5 nM
The estimate for compound 3 lay 360-fold (2.56 log units) above the measured number; measured number outside the range, below it.
By their numbers in this assay, from the lowest: compound 3; then compounds 2 and 1 (each within the scatter of the next).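

In this assay, going by these compounds alone, placing diethylamino on the saturated chain carbon of the 4-methylphenyl group produces a large change (a 510-fold lower number from compound 2 to compound 3 (2.71 log units; beyond the scatter)), while the only earlier step (a 1.3-fold lower number from compound 1 to compound 2 (0.12 log units; within the scatter)) stayed within the scatter. This shows that the outer end of this aryl group, untouched by the earlier comparison, can matter greatly: 4-((diethylamino)methyl)phenyl in place of pyrrolidin-1-yl also gives a large step (a 660-fold lower number from compound 1 to compound 3 (2.82 log units; beyond the scatter)), which makes compound 3 the strongest of the three compounds here. Nothing at hand explains why this one added group has so large an effect.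

Going by these compounds, it remains open whether the gain needs diethylamino itself, or whether a smaller amine such as dimethylamino, a ring amine such as morpholine or piperidine, or a non-amine group such as hydroxyl on the same carbon would give a similar number. Also open, on these data alone, is whether a longer chain carrying the amine would keep the number as low as that of compound 3, which would help show how closely this large step depends on the exact group.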